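Swapping the Pyrazole for an Imidazole on the Piperazine Arm

A few compounds are considered here, and "the series" means these few. Any claim that something is new, unique, unknown or untested is made for them only; others in the source may bear on it.

In an assay on isolated protein for displacement of a labelled ligand from Gonadotropin-releasing hormone receptor (Homo sapiens) (on this read-out higher numbers stand for weaker inhibition and lower numbers for stronger inhibition), compound 1 `Cc1nc(C)c(CN2CCN(c3cccc4[nH]c(-c5ccc(C(C)(C)C)cc5)nc34)CC2)o1` gives 31 nM.
In this assay compound 2 `CCc1nc(C)c(CN2CCN(c3cccc4[nH]c(-c5ccc(C(C)(C)C)cc5)nc34)CC2)s1` gives 20 nM.
In this assay compound 3 `Cc1n[nH]c(C)c1CN1CCN(c2cccc3[nH]c(-c4ccc(C(C)(C)C)cc4)nc23)CC1` gives 68 nM.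

Compound 3 has the highest number of the three measured compounds: a 2.2-fold higher number from compound 1 to compound 3 (0.34 log units; beyond the scatter), and a 3.4-fold higher number from compound 2 to compound 3 (0.53 log units; beyond the scatter). Compound 4 `CCCn1c(CC)nc(C)c1CN1CCN(c2cccc3[nH]c(-c4ccc(C(C)(C)C)cc4)nc23)CC1` has not been measured. It differs from compound 3 in one place: 2-ethyl-4-methyl-1-propyl-1H-imidazol-5-yl in place of 3,5-dimethyl-1H-pyrazol-4-yl on a saturated chain carbon bound to an amine nitrogen in a ring. Both measured steps bear on this change, since the ring that leaves is the only one among the three carrying a hydrogen-bond donor, and the two rings without a donor gave lower numbers. The ring that enters likewise has no donor, so a modest fall is expected: a 2.7-fold lower number from compound 3 to compound 4 (0.43 log units; beyond the scatter). Compound 4 is therefore estimated at 25 nM in this assay, with a range from 9 nM to 70 nM.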

Compound 4, half-maximal inhibitory concentration: 57 nM
Beside the measured number, compound 4's estimate is 2.3-fold (0.36 log units) below it, and the stated range covers the measured number.
By their numbers in this assay, from the lowest: compounds 2, 1, 4 and 3 (each within the scatter of the next, the first and the last beyond it).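

In this assay the change gives a 1.2-fold lower number from compound 3 to compound 4 (0.08 log units; within the scatter) even though the hydrogen-bond donor is gone, so the donor count alone does not sort these rings, even with 11 heavy atoms in place of 7. Of the other two rings without a donor, only one is clearly apart, with a 2.9-fold higher number from compound 2 to compound 4 (0.45 log units; beyond the scatter) while a 1.8-fold higher number from compound 1 to compound 4 (0.26 log units; within the scatter) stays inside the scatter. No measured evidence accounts for these differences. Going by these compounds, whether the 1-propyl chain matters on its own remains open. The same imidazole with a butyl chain or a hydrogen in place of the propyl would test that.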